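Acyl guanidines on the shared core: microsomal half-life

The compounds below may be only part of what the source reports. "The series", "measured", "known", "first", "only" and "open" are said of these compounds alone.

Measured so far in an in vitro ADME assay on microsomes from liver (Mus musculus) for metabolic stability, read by LC-MS, tested at 1 uM; a lower number here means that the compound disappears faster, a higher number that the compound lasts longer:
Compound 1 `CC(C)N/C(=N\c1nccn1C(C)C)Nc1ccc(Cl)c(Cl)c1` gives 0.0983 h.
Compound 2 `CC(C)C(=O)N/C(=N/c1nccn1C(C)C)Nc1ccc(Cl)c(Cl)c1` gives > 1 h, a limit of the assay.
Compound 3 `CCC(CC)C(=O)N/C(=N/c1nccn1C(C)C)Nc1ccc(Cl)c(Cl)c1` gives > 1 h, also a limit of the assay.

Compound 3 therefore stands at the limit where two of the three values sit (the limit of > 1 h in this assay, at which 2 of the 3 values shown sit), and the size of the step that the two limits leave unreadable from compound 2 to compound 3 cannot be read. Among the compounds with values here, compound 1 gives a plain number, but no single step links it to compound 2 or to compound 3. Compound 4 `CC(C)n1ccnc1/N=C(/NC(=O)C(C)(C)C)Nc1ccc(Cl)c(Cl)c1` differs from compound 3 by tert-butyl in place of pentan-3-yl on a carbonyl carbon. Within the data shown here, the only measured step at a carbonyl carbon, a step that the two limits leave unreadable from compound 2 to compound 3, is unreadable, so the expected step that the limit leaves unreadable from compound 3 to compound 4 is set at none beyond the scatter. Compound 4 is expected to give 1.5 h in this assay, within the range 0.6 h to 4 h, most likely reported again as a limit.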

Compound 4, half-life: > 1 h
Compound 4 gave a limit, no number; the forecaster's own chance of this, stated with the estimate: 70%; the middle value does not contradict the limit.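

Within the data shown here, compound 4 gives > 1 h, a limit of the assay, and no step to it from compound 2 or compound 3 can be read. The compounds shown leave open whether the half-lives of compound 2, compound 3 and compound 4 differ at all: the limit of > 1 h in this assay, at which 3 of the 4 values shown sit.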